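The source may report more compounds than this note shows. Statements on the series, on what has been measured and on what is new or still open speak of the compounds shown alone.

Values in a functional assay on MV4-11 cells (Homo sapiens) for inhibition, read by resazurin assay, with a stated time of 72 h; on this read-out higher numbers stand for weaker inhibition of growth and lower numbers for stronger inhibition of growth:
- Compound 1 `O=C1NCCC12CCN(c1c(Cl)cncc1-c1ccoc1)CC2`: 750 nM
- Compound 2 `O=C1NCCC12CCN(c1c(Cl)cncc1-c1ccsc1)CC2`: 190 nM
- Compound 3 `CC(=O)c1sccc1-c1cncc(Cl)c1N1CCC2(CCNC2=O)CC1`: > 100000 nM, a limit of the assay and not a number

Compound 3 therefore has no measured number, only (the limit of > 100000 nM in this assay, at which 1 of the 3 values shown sits). Compound 4 `O=C1NCCC12CCN(c1c(Cl)cncc1-c1cn[nH]c1)CC2` has not yet been measured. It carries 1H-pyrazol-4-yl in place of 2-acetylthiophen-3-yl on an aromatic carbon.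

The acetyl group leaves in this change, so the step that bears most directly on it is the large one that added that group, an at least 520-fold higher number from compound 2 to compound 3 (2.72 log units; beyond the scatter). The comparison with the furan-3-yl compound is also large: an at least 130-fold higher number from compound 1 to compound 3 (2.12 log units; beyond the scatter). By contrast, exchanging one ring without acetyl for another was only a modest step: a 3.9-fold lower number from compound 1 to compound 2 (0.60 log units; beyond the scatter).

Compound 4 also lacks the acetyl, so it is expected to sit near compound 1 at 750 nM and compound 2 at 190 nM. The pyrazole itself has not been tested on this core, so the range stays wide. A large move to a lower number is expected, and the estimated step is an at least 250-fold lower number from compound 3 to compound 4 (2.39 log units; beyond the scatter). For compound 4 the estimated value in this assay is 400 nM, with an expected range of 60 nM to 3000 nM.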

Compound 4, concentration for 50% growth inhibition: 8520 nM
Beside the measured number, compound 4's estimate is 21-fold (1.33 log units) below it, and the stated range ends below it.
By their numbers in this assay, from the lowest: compound 2; then compound 1; then compound 4. At a limit, above all of these: compound 3.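

Compound 3 stands at a limit and not a number, so the gain from its replacement has only a floor: (the limit of > 100000 nM in this assay, at which 1 of the 4 values shown sits). In this assay, losing the 2-acetylthiophen-3-yl group does lift the block (an at least 11-fold lower number from compound 3 to compound 4 (1.06 log units; beyond the scatter)), but 1H-pyrazol-4-yl on this aromatic carbon does not return to the level of the other rings without acetyl, standing well above both the furan-3-yl ring (an 11-fold higher number from compound 1 to compound 4 (1.06 log units; beyond the scatter)) and the thiophen-3-yl ring (a 45-fold higher number from compound 2 to compound 4 (1.65 log units; beyond the scatter)). The absence of the acetyl is thus not sufficient on its own, and the choice of five-membered ring carries far more weight here than the modest exchange of furan-3-yl for thiophen-3-yl suggested (a 3.9-fold lower number from compound 1 to compound 2 (0.60 log units; beyond the scatter)).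

The compounds shown cannot tell which difference between 1H-pyrazol-4-yl and the other two rings lies behind the higher number of compound 4, and the hydrogen on the pyrazole nitrogen is only one candidate. They also leave open how a 1-methylpyrazol-4-yl, phenyl or pyridin-3-yl ring would stand at this position on the shared core.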